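The source may hold more compounds than are shown below. What is called first, only, known or untested is meant among the compounds shown, and "the series" means these compounds.

Measured compounds in hand:

compound 1 `CCn1c(C(=O)NCCCN(C)C)ccc1C(CC)(CC)c1ccc(OCCC(O)(CC)CC)c(C)c1` — 5 nM
compound 2 `CCN(CC)CCNC(=O)c1ccc(C(CC)(CC)c2ccc(OCCC(O)(CC)CC)c(C)c2)n1CC` — 2.3 nM
compound 3 `CCC(C)C(NC(=O)c1ccc(C(CC)(CC)c2ccc(OCCC(O)(CC)CC)c(C)c2)n1CC)C(=O)O` — 860 nM

In an assay on cells for agonist activity at vitamin D3 receptor (Homo sapiens), with a stated time of 96 h (a lower number here means that less compound is needed, a higher number that more compound is needed for the effect), compound 1 gives 5 nM and compound 2 gives 2.3 nM; the step of a 2.2-fold lower number from compound 1 to compound 2 (0.34 log units; beyond the scatter) is modest. Compound 3 gives 860 nM in this assay and stands as the highest number of the three, with a 170-fold higher number from compound 1 to compound 3 (2.24 log units; beyond the scatter) and a 370-fold higher number from compound 2 to compound 3 (2.57 log units; beyond the scatter) both large. Compound 3 is thus the one of the three for which the most compound is needed.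

Compound 4 `CCn1c(C(=O)NC(CC(=O)O)C(=O)OC)ccc1C(CC)(CC)c1ccc(OCCC(O)(CC)CC)c(C)c1` is not yet measured. It differs from compound 3 in one place: a group of 9 heavy atoms (5 carbon, 4 oxygen; no ring) in place of a group of 8 heavy atoms (6 carbon, 2 oxygen; no ring), on an amide-type nitrogen. The two steps that bear on this change are the two large ones into compound 3, where a 1-carboxy-2-methylbutyl group on the amide-type nitrogen replaced an amine-bearing chain. Among the compounds with values here, no measured step compares two different groups of this kind on the amide-type nitrogen with each other, so the size of the present step is not anchored by a direct precedent. Given that the group on the amide-type nitrogen remains an acid-bearing one of similar size, the expectation for compound 4 is a number close to that of compound 3, a 1.1-fold lower number from compound 3 to compound 4 (0.03 log units; within the scatter), within the scatter or not far beyond it. Compound 4 is therefore estimated at 800 nM in this assay, with a range of 200 nM to 3500 nM.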

Compound 4, half-maximal effective concentration: 26 nM
Beside the measured number, compound 4's estimate is 31-fold (1.49 log units) above it, outside the stated range (below it).
By their numbers in this assay, from the lowest: compound 2; then compound 1; then compound 4; then compound 3.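

Working notes on the group on the amide-type nitrogen. In this assay, a carboxy group in that group does not by itself fix a high number: both the group that leaves and the group that enters carry one, yet the change gives a 33-fold lower number from compound 3 to compound 4 (1.52 log units; beyond the scatter). The earlier compounds shown here compared only amine-bearing chains with a single carboxy-bearing group. The large steps into compound 3 all lie between those two kinds of group; this step shows that the carboxy-bearing groups also differ widely among themselves. The amine-bearing chains still give the lowest numbers, with an 11-fold higher number from compound 2 to compound 4 (1.05 log units; beyond the scatter) and the smaller 5.2-fold higher number from compound 1 to compound 4 (0.72 log units; beyond the scatter), so the new group narrows the gap without closing it.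

Going by these compounds, it remains open whether the methyl ester or the loss of the branched alkyl part of 1-carboxy-2-methylbutyl accounts for the step. A second carboxylic acid in place of the methyl ester, or a longer chain carrying the carboxy group, would help separate these two changes. No measurement at hand explains the size of this step.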